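Swapping a Methyl for a Phenyl on the Amino Nitrogen

The source may report more compounds than this note shows. Statements on the series, on what has been measured and on what is new or still open speak of the compounds shown alone.

Compound 1 `CNc1nnc(-c2cc(-c3ccc(F)cc3F)ccc2O)o1` carries a methylamino group on its core. Among the measured compounds shown here, in a functional assay on the whole organism (strain BALB/c) for inhibition, with Mus musculus as the target, read by paw edema, with a stated time of 4 h, at a dose of 50 mg/kg by the oral route (on this read-out higher numbers stand for more inhibition at the one dose given (going by the name of the read-out) and lower numbers for less inhibition), compound 1 gives 41.4%, and it stands alongside the only other measured compound, compound 2 `CNc1nnc(-c2cc(-c3ccc(F)cc3F)ccc2O)s1`, which in this assay gives 45.4%; the step of a number 4 percentage points higher from compound 1 to compound 2 (within the scatter) changes only the ring bearing the amino group.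

Compound 3 `Oc1ccc(-c2ccc(F)cc2F)cc1-c1nnc(Nc2ccccc2)o1` differs from compound 1 by phenyl in place of methyl on a nitrogen on an aromatic ring, the same difference reading methylamino to anilino one bond further out. For the measured compounds named here, no measured step touches the amino substituent, so nothing measured bears directly on this change, and the two values at hand sit within the scatter of each other. On that basis the step of a number 0.4 percentage points lower from compound 1 to compound 3 (within the scatter) is expected to stay within the usual scatter, with no firm direction. Compound 3 is therefore estimated to give 41% in this assay, within a range from 26% to 56%.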

Compound 3, a percentage reported as inhibition, in the whole organism at one dose (the size of the read-out at that dose, not a potency): 39.5%
For compound 3 the middle estimate is 1.5 percentage points above the measured one; measured number inside the range.
By their numbers in this assay, from the lowest: compounds 3, 1 and 2 (each within the scatter of the next).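

Among the compounds shown here, the earlier compounds differed only in the ring bearing the amino group, so this is the first reading on the substituent on that nitrogen itself. In this assay, the step of a number 1.9 percentage points lower from compound 1 to compound 3 (within the scatter) shows that phenyl, with six heavy atoms and an aromatic ring, can stand in place of the single carbon of methyl while the two values stay within the scatter of each other. Nothing measured here offers a reason for this outcome.

As far as these compounds go, whether the same holds for other groups on this nitrogen remains open, such as a longer chain like butyl, a benzyl group, or a phenyl carrying a carboxylic acid. From the compounds shown here alone, it is also open how phenyl in place of methyl would read on the core of compound 2.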